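Hydroxyl Enters the Side Chain of Compound 2

The source may report more compounds than this note shows. Statements on the series, on what has been measured and on what is new or still open speak of the compounds shown alone.

Compound 1 `CC(C)=CCc1cc(/C=C2\OC(=O)C(c3ccc(O)cc3O)=C2O)ccc1O` and compound 2 `CC(C)=CCc1cc(/C=C2\OC(=O)C(c3cc(CC=C(C)C)c(O)cc3O)=C2O)ccc1O` share one core. In a functional assay on J774.1 cells (Mus musculus), read by LDH release, with a stated time of 1 h, in the presence of a further agent that is not named here (on this read-out higher numbers stand for weaker inhibition and lower numbers for stronger inhibition), compound 1 gives 2400 nM, and compound 2 gives 3000 nM. Compound 2 thus holds the highest of the two numbers shown, yet the step of a 1.3-fold higher number from compound 1 to compound 2 (0.10 log units; within the scatter) is within the scatter. Compound 3 `CC(C)=CCc1cc(/C=C2\OC(=O)C(c3cc(CCC(C)(C)O)c(O)cc3O)=C2O)ccc1O` arises from compound 2 by 2-hydroxy-2-methylpropyl in place of 2-methylprop-1-en-1-yl on a saturated chain carbon bound to an aromatic carbon. Among the measured compounds shown here, no measured step bears directly on this change; the only step available, a 1.3-fold higher number from compound 1 to compound 2 (0.10 log units; within the scatter), is small. Compound 3 is therefore expected to show no step beyond the scatter, no change at the digits printed from compound 2 to compound 3 (within the scatter), with an estimated 3000 nM and a range from 1200 nM to 7500 nM.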

Compound 3, half-maximal inhibitory concentration: 3300 nM
Estimate against measurement, compound 3: 1.1-fold (0.04 log units) below, and the stated range covers the measured number.
By their numbers in this assay, from the lowest: compounds 1, 2 and 3 (each within the scatter of the next).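

In this assay, 2-hydroxy-2-methylpropyl in place of 2-methylprop-1-en-1-yl gives a 1.1-fold higher number from compound 2 to compound 3 (0.04 log units; within the scatter) and so shows that, on this saturated chain carbon bound to an aromatic carbon, a chain can lose its double bond and take a hydrogen-bond donor and acceptor without a step beyond the scatter. Set against hydrogen on the aromatic carbon, 3-hydroxy-3-methylbutyl gives a 1.4-fold higher number from compound 1 to compound 3 (0.14 log units; within the scatter) and so stays within the scatter, as 3-methylbut-2-en-1-yl did. No evidence is available that would explain these results. On these data alone, whether an amine, a carboxylic acid or a longer chain at this place would also stay within the scatter remains open.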